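A methyl step from compound 2

The source may hold more compounds than are shown below. What is called first, only, known or untested is meant among the compounds shown, and "the series" means these compounds.

In a functional assay on the whole organism for antagonist activity, with Mus musculus as the target (a higher number here means that more compound is needed for the effect, a lower number that less compound is needed), compound 1 (`CC(=O)N(C)CC#CCn1cncc1C`) gives 6.6 mg/kg as the lower number. Compound 2 (`CCOC(=O)N(C)CC#CCn1ccnc1`) gives 97 mg/kg as the higher number, and the gap between the two lies beyond the scatter. Compound 3 (`CCOC(=O)N(C)CC#CCn1cncc1C`) has methyl in place of hydrogen on an aromatic carbon of compound 2 methyl in place of hydrogen on an aromatic carbon and shares that methyl with compound 1. Among the measured compounds shown here, no measured pair isolates this change, so the expectation is tentative. The estimated step of a 4.9-fold lower number from compound 2 to compound 3 (0.69 log units; beyond the scatter) runs towards a lower number, beyond the scatter. For compound 3 the expected value is 20 mg/kg with a range of 6 mg/kg to 70 mg/kg in this read-out.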

Compound 3, dose for half-maximal effect: 66 mg/kg
Compound 3: middle estimate off by 3.3-fold (0.52 log units), on the low side; low and high end bracket the measured number.
By their numbers in this assay, from the lowest: compound 1; then compounds 3 and 2 (each within the scatter of the next).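

In this assay, methyl in place of hydrogen on an aromatic carbon gives a 1.5-fold lower number from compound 2 to compound 3 (0.17 log units; within the scatter), so with ethoxy on the carbonyl carbon this ring position shows no change beyond the scatter. Ethoxy in place of methyl on a carbonyl carbon gives a 10-fold higher number from compound 1 to compound 3 (1.00 log units; beyond the scatter), and of the two changes only this one lies beyond the scatter. No measured evidence accounts for either step. Going by these compounds, the methyl step is read only with ethoxy on the carbonyl carbon, so its size with methyl there stays open. Also open, on these data alone, is how a longer chain such as butoxy, or an amine, would read on that carbonyl carbon.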